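The source may hold more compounds than are shown below. What is called first, only, known or untested is meant among the compounds shown, and "the series" means these compounds.

Compound 1 `Cc1c(/N=C/c2cccc(O)c2)c(=O)n(-c2ccccc2)n1C` was tested in a functional assay on HT-29 cells (Homo sapiens) for cytotoxicity, read by MTT assay, with a stated time of 72 h (on this read-out higher numbers stand for weaker inhibition and lower numbers for stronger inhibition), where compound 1 gives 166000000 nM. This is the lowest of the two numbers recorded in this assay, but the only companion, compound 2 `COc1cccc(/C=N/c2c(C)n(C)n(-c3ccccc3)c2=O)c1O`, gives 240000000 nM, and the gap between these two readings is within the usual scatter, so neither can be called the stronger of the pair. Compound 3 `Cc1c(/N=C/c2ccc(Cl)cc2Cl)c(=O)n(-c2ccccc2)n1C` has not yet been measured in this assay. It differs from compound 1 in one place: 2,4-dichlorophenyl in place of 3-hydroxyphenyl on a carbon with a double bond to nitrogen. Going by the values given here, no step between measured compounds with this particular exchange is available, so the expectation for compound 3 rests only on the two readings above, both of which sit at very weak inhibition. Against that background compound 3 is expected to give 100000000 nM, within a range from 20000000 nM to 300000000 nM. The step this estimate implies, a 1.7-fold lower number from compound 1 to compound 3 (0.22 log units; within the scatter), is expected to be small and is not expected to exceed the scatter of repeated measurements in this assay.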

Compound 3, half-maximal inhibitory concentration: 178000000 nM
Compound 3: middle estimate off by 1.8-fold (0.25 log units), on the low side; measured number inside the range.
By their numbers in this assay, from the lowest: compounds 1, 3 and 2 (each within the scatter of the next).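

In this assay, going by these compounds alone, putting 2,4-dichlorophenyl in place of 3-hydroxyphenyl on a carbon with a double bond to nitrogen amounts to a 1.1-fold higher number from compound 1 to compound 3 (0.03 log units; within the scatter), which is the first direct reading of an exchange at this position. The leaving group carries a hydrogen-bond donor and acceptor and the entering group carries neither, yet this read-out does not separate the two, so in this pair the hydroxyl is not required for the level of inhibition seen, and two chlorine substituents do not alter that level beyond the scatter. Nothing available explains why the two groups read alike, and this single exchange gives no grounds for a cause.

On these data alone, both compounds of this pair sit at very weak inhibition, so it remains open whether this position can shift the reading at all or whether the exchange merely shows no difference at that level. As far as these compounds go, whether a phenyl bearing an amine or a carboxylic acid, or a longer alkyl chain in place of the aromatic ring, would move the number beyond the scatter also remains open.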